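The source may hold more compounds than are shown below. What is called first, only, known or untested is meant among the compounds shown, and "the series" means these compounds.

Measured in a functional assay on WiDr cells (Homo sapiens) for antiproliferative activity, read by sulforhodamine B assay, with a stated time of 48 h; a higher number here means a weaker inhibitor of growth, a lower number a stronger inhibitor of growth:
- compound 1 `CC(C)(C)[Si](C)(C)OC[C@H]1OCCC[C@H]1O[Si](C)(C)C(C)(C)C`: > 100000 nM
- compound 2 `CC(C)(C)[Si](C)(C)O[C@@H]1CCCO[C@@H]1CO`: > 100000 nM
- compound 3 `O=C(/C=C/[C@H]1OCCC[C@H]1O)OCc1ccccc1`: > 100000 nM

All three values are limits, not numbers. Among the measured compounds shown here, the series so far stands at the limit of > 100000 nM in this assay, at which 3 of the 3 values shown sit, so compound 2 has no readable position of its own.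

Compound 4 `COC(=O)/C=C\[C@H]1OCCC[C@H]1O[Si](C)(C)C(C)(C)C` differs from compound 2 by one change: 2-(methoxycarbonyl)ethenyl in place of hydroxymethyl on a saturated ring carbon.

For the measured compounds named here, the only measured step is a step that the two limits leave unreadable from compound 1 to compound 2, and it gives no size to carry over. With no readable precedent, no large step is expected in this assay, and any movement would be toward stronger growth inhibition. The expected step is an at least 1.2-fold lower number from compound 2 to compound 4 (0.09 log units; that floor lies within the scatter).

Compound 4 is estimated at 80000 nM, with an expected range of 25000 nM to 150000 nM, and the assay may well report only a limit.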

Compound 4, concentration for 50% growth inhibition: 38000 nM
The estimate for compound 4 lay 2.1-fold (0.32 log units) above the measured number; the measured number falls inside the stated range.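

In this assay, compound 4 is the only compound shown that gives a number rather than a limit: the limit of > 100000 nM in this assay, at which 3 of the 4 values shown sit. Placing 2-(methoxycarbonyl)ethenyl in place of hydroxymethyl on this saturated ring carbon gives an at least 2.6-fold lower number from compound 2 to compound 4 (0.42 log units; beyond the scatter), the first readable step in the series and evidence that this position can move the read-out. Even so, compound 4 remains a weak inhibitor of growth at 38000 nM.

As far as these compounds go, it remains open whether the methoxycarbonyl part or the ethenyl part carries this step. From the compounds shown here alone, it is also open whether a carboxylic acid, an amide or a longer chain here would lower the number further.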